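Side-chain notes on the shared core before compound 3

A few compounds are considered here, and "the series" means these few. Any claim that something is new, unique, unknown or untested is made for them only; others in the source may bear on it.

Measured so far:
compound 1 `COc1ccc2nc(C)cc(OCC(=O)Nc3ccccc3Cl)c2c1`: > 140000 nM
compound 2 `COc1ccc2nc(C)cc(OCC(=O)NCCCc3ccccc3)c2c1`: > 137000 nM

In an ADME assay on HepG2 cells (Homo sapiens) for cytotoxicity, read by trypan blue exclusion, with a stated time of 48 h, in the presence of a further agent that is not named here (on this read-out lower numbers stand for higher toxicity in this test and higher numbers for lower toxicity in this test), compound 1 reaches only a limit, > 140000 nM. Compound 2 likewise reaches only a limit, > 137000 nM. The step that the two limits leave unreadable from compound 1 to compound 2 is therefore unreadable. Within the data shown here, compound 2 thus stands at a limit, and the one other value shown is a limit too.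

Compound 3 `CCCCCNC(=O)COc1cc(C)nc2ccc(OC)cc12` differs from compound 2 by ethyl in place of phenyl on a saturated chain carbon, three bonds along the chain from an amide-type nitrogen. Among the measured compounds shown here, no measured step bears readably on this change; the evidence is only the limit of > 137000 nM in this assay, at which 1 of the 2 values shown sits, and (the limit of > 140000 nM in this assay, at which 1 of the 2 values shown sits). The expected step that the limit leaves unreadable from compound 2 to compound 3 is none beyond the scatter. Compound 3 is estimated at 140000 nM (range 70000 nM to 280000 nM), most likely reported again as a limit.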

Compound 3, half-maximal cytotoxic concentration: > 158000 nM
Compound 3: a limit, no number; the forecaster's own chance of this, stated with the estimate: 80%; at least 1.1-fold (0.05 log units) between middle value and limit.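

In this assay compound 3 gives > 158000 nM, which is a limit. Among these compounds, compound 1 and compound 2 also stand at limits, so no step among the three can be read. The compounds shown leave open whether any of these side chains on the shared core gives a numerical half-maximal cytotoxic concentration.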